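Working notes: chloro in place of hydrogen on compound 2

The source may hold more compounds than are shown below. What is called first, only, known or untested is meant among the compounds shown, and "the series" means these compounds.

Measured so far in a functional assay on RAW264.7 cells (Mus musculus), with a stated time of 3 days (a higher number here means a weaker inhibitor, a lower number a stronger inhibitor), as follows
- compound 1 `COc1cnc(-c2ccccn2)nc1NCc1ccccc1C(F)(F)F` gives 230 nM in this series
- compound 2 `COc1cnc(-c2ccccn2)nc1NCc1ccccc1` gives 420 nM in this series

Within the data shown here, compound 2 at 420 nM stands within the scatter of compound 1, the only other measured compound. Compound 3 `COc1cnc(-c2ccccn2)nc1NCc1ccccc1Cl` differs from compound 2 by one change chloro in place of hydrogen on an aromatic carbon with chloro in place of hydrogen on an aromatic carbon, ortho to a large group. Among the measured compounds shown here, the one step bearing on this is a 1.8-fold higher number from compound 1 to compound 2 (0.26 log units; within the scatter) and it exchanges hydrogen and trifluoromethyl on an aromatic carbon. From that step, no change beyond the scatter is expected in this assay and any lean would be toward a lower number. For compound 3 the estimated value is 300 nM with an expected range from 130 nM to 650 nM in this assay. The expected step is a 1.4-fold lower number from compound 2 to compound 3 (0.15 log units; within the scatter) on this estimate.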

Compound 3, half-maximal inhibitory concentration: 520 nM
Compound 3: middle estimate off by 1.7-fold (0.24 log units), on the low side, and the stated range covers the measured number.
By their numbers in this assay, from the lowest: compounds 1, 2 and 3 (each within the scatter of the next, the first and the last beyond it).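

In this assay, chloro in place of hydrogen at this position, ortho to a large group, gives a 1.2-fold higher number from compound 2 to compound 3 (0.09 log units; within the scatter), so these two substituents cannot be told apart here. Chloro in place of trifluoromethyl gives a 2.3-fold higher number from compound 1 to compound 3 (0.35 log units; beyond the scatter), the only step in the series beyond the scatter, and it is modest. No measurement at hand accounts for this step.

Still open, as far as these compounds go, is whether an amine or a carboxylic acid at this position would stand clearly apart from hydrogen, and whether the same substituents behave alike elsewhere on that ring.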